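Isoindolinone-amide series: bromine position on the N-phenyl ring

A few compounds are considered here, and "the series" means these few. Any claim that something is new, unique, unknown or untested is made for them only; others in the source may bear on it.

Measured compounds in a functional assay on HT-29 cells (Homo sapiens) for cytotoxicity, read by MTT assay, with a stated time of 72 h; a lower number here means a stronger inhibitor, a higher number a weaker inhibitor:
compound 1 `COc1cc2c(Oc3ccc(NC(=O)c4nn(-c5ccccc5)c(=O)c5ccccc45)cc3F)ccnc2cc1OCCCN1CCN(C)CC1`: 1140 nM
compound 2 `COc1cc2c(Oc3ccc(NC(=O)c4nn(-c5ccccc5F)c(=O)c5ccccc45)cc3F)ccnc2cc1OCCCN1CCN(C)CC1`: 480 nM
compound 3 `COc1cc2c(Oc3ccc(NC(=O)c4nn(-c5ccc(Br)cc5)c(=O)c5ccccc45)cc3F)ccnc2cc1OCCCN1CCN(C)CC1`: 850 nM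

Compound 3 sits second highest of the three numbers in this assay. Its nearest neighbour is compound 1, a step of a 1.3-fold lower number from compound 1 to compound 3 (0.13 log units; within the scatter) that stays within the scatter; its furthest is compound 2, where a 1.8-fold higher number from compound 2 to compound 3 (0.25 log units; within the scatter) also stays within the scatter. Among the compounds with values here, the only step beyond the scatter is a 2.4-fold lower number from compound 1 to compound 2 (0.38 log units; beyond the scatter).

Compound 4 `COc1cc2c(Oc3ccc(NC(=O)c4nn(-c5ccccc5Br)c(=O)c5ccccc45)cc3F)ccnc2cc1OCCCN1CCN(C)CC1` is the next entry. It differs from compound 3 by 2-bromophenyl in place of 4-bromophenyl on an aromatic nitrogen; the two share the same atoms, joined differently.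

Within the data shown here, two measured steps bear on this. The 2-fluorophenyl analogue, compound 2, gave the lowest number through a 2.4-fold lower number from compound 1 to compound 2 (0.38 log units; beyond the scatter), whereas the 4-bromophenyl analogue gave only a 1.3-fold lower number from compound 1 to compound 3 (0.13 log units; within the scatter). Placing the bromine as in compound 2's fluorine is therefore expected to shift the number toward compound 2, but the gap between compound 2 and compound 3 lies within the scatter, so only a small change is expected. For compound 4 the estimated step is a 1.5-fold lower number from compound 3 to compound 4 (0.19 log units; within the scatter), a modest lower number, not clearly beyond the scatter. Compound 4 is expected to give 550 nM, with a range of 250 nM to 1200 nM.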

Compound 4, half-maximal inhibitory concentration: 1190 nM
For compound 4 the middle estimate is 2.2-fold (0.34 log units) below the measured one; low and high end bracket the measured number.
By their numbers in this assay, from the lowest: compounds 2, 3, 1 and 4 (each within the scatter of the next, the first and the last beyond it).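

Within this assay, 2-bromophenyl in place of 4-bromophenyl on the ring nitrogen gives a 1.4-fold higher number from compound 3 to compound 4 (0.15 log units; within the scatter) and so does not separate the two bromine placements, while bromo in place of hydrogen at this position gives a 1.0-fold higher number from compound 1 to compound 4 (0.02 log units; within the scatter) and leaves compound 4 indistinguishable from the unsubstituted phenyl of compound 1. The identity of the halogen at this same position does separate two compounds: bromo in place of fluoro gives a 2.5-fold higher number from compound 2 to compound 4 (0.39 log units; beyond the scatter) and is a modest step, so the gain seen with fluoro in compound 2 does not carry over to bromo in compound 4. No measurement at hand offers an explanation for this difference between the two halogens.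

As far as these compounds go, whether the separation from compound 4 is specific to fluoro or also holds for other groups at this position, such as chloro, methyl or methoxy, remains open. The compounds shown also leave open how a 4-fluorophenyl would compare with compound 2 and compound 3, and whether an amine or a carboxylic acid on this ring would give a step beyond the scatter.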